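The compounds below may be only part of what the source reports. "The series", "measured", "known", "first", "only" and "open" are said of these compounds alone.

Measured compounds in a functional assay on HT-29 cells (Homo sapiens) for cytotoxicity, read by MTT assay, with a stated time of 72 h; a lower number here means a stronger inhibitor of growth, a higher number a weaker inhibitor of growth:
Compound 3 `COc1ccc(CNc2nc(SC)nc3ccccc23)cc1` gives 70200 nM
Compound 1 `CCCCC[Se]c1nc(NCc2ccc(SC)cc2)c2ccccc2n1` gives 83600 nM
Compound 2 `CSc1ccc(CNc2nc([SeH])nc3ccccc23)cc1` gives 42900 nM

Compound 3 sits in the middle of these three numbers, within the scatter of both compound 1 and compound 2. Compound 4 `CSc1ccc(CNc2nc(SC)nc3ccccc23)cc1` differs from compound 3 only by methylsulfanyl in place of methoxy on an aromatic carbon. Among the compounds with values here, the one measured step, a 1.9-fold lower number from compound 1 to compound 2 (0.29 log units; within the scatter), swaps a group on selenium and says nothing about an exchange of methoxy for methylsulfanyl; no measured pair shows that exchange. Within the data shown here, with all three values within scatter of one another and no step bearing on the change, compound 4 is expected to stay close to compound 3, a step of a 1.0-fold lower number from compound 3 to compound 4 (0.00 log units; within the scatter) in this assay. Compound 4 is therefore estimated at 70000 nM, within a range from 35000 nM to 140000 nM.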

Compound 4, concentration for 50% growth inhibition: 34700 nM
Estimate against measurement, compound 4: 2.0-fold (0.30 log units) above; the whole stated range lies above it.
By their numbers in this assay, from the lowest: compounds 4, 2, 3 and 1 (each within the scatter of the next, the first and the last beyond it).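

In this assay, methylsulfanyl in place of methoxy on the aromatic carbon gives a 2.0-fold lower number from compound 3 to compound 4 (0.31 log units; beyond the scatter), so this position does respond to the exchange, though modestly. At the group on the other aromatic carbon, a 1.2-fold lower number from compound 2 to compound 4 (0.09 log units; within the scatter), whereas a 2.4-fold lower number from compound 1 to compound 4 (0.38 log units; beyond the scatter), so the pentyl-bearing selenium group and methylsulfanyl do differ measurably. No measurement here accounts for either shift. Still open, on these data alone, is whether a longer sulfur chain, such as ethylsulfanyl, or an amine at the same aromatic carbon would move the number further.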